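The source may report more compounds than this note shows. Statements on the series, on what has been measured and on what is new or still open speak of the compounds shown alone.

The measured compounds:

Compound 1 `CC(C)(C)c1ccc(C(=O)NC(=S)N2CCc3c(OCCCCCOc4ccc(Cl)cc4)cccc32)cc1` — in an ADME assay on Huh-7 cells (Homo sapiens) for cytotoxicity (a higher number here means that more compound is tolerated, a lower number that less compound is tolerated), compound 1 gives > 50000 nM, which is a limit of the assay rather than a number.
Compound 2 `O=C(NC(=S)N1CCc2c(OCCCCCOc3ccc(Cl)cc3)cccc21)C1CCCCC1` — in this assay compound 2 gives > 50000 nM, again a limit of the assay and not a number.

The step that the two limits leave unreadable from compound 1 to compound 2 cannot be read in size or direction, since both ends are limits (the limit of > 50000 nM in this assay, at which 2 of the 2 values shown sit). Within the data shown here, compound 2 therefore stands at the limit of this assay, with the one other value shown sitting at the same limit; no measured compound in this set has a readable number.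

Compound 3 `O=S(=O)(NC(=S)N1CCc2c(OCCCCCOc3ccc(Cl)cc3)cccc21)c1ccccc1` differs from compound 2 by phenylsulfonyl in place of cyclohexylcarbonyl on an amide-type nitrogen. No measured step bears on this change: the only step shown, that from compound 1 to compound 2, is unreadable, so there is no comparison to carry over. What the data do give is that both measured compounds tolerate the highest concentration tested, and compound 3 shares their core.

Compound 3 is therefore expected to sit at the limit as well, an expected step of a number no higher from compound 2 to compound 3 (the limit leaves the size open). The estimate for compound 3 in this assay is 50000 nM, with a range from 20000 nM to 100000 nM.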

Compound 3, half-maximal cytotoxic concentration: > 50000 nM
Compound 3: only a limit was reported; the forecaster's own chance of this, stated with the estimate: 80%; the middle value sits exactly at the limit.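

In this assay compound 3 gives > 50000 nM, which is a limit of the assay and not a number. The steps from compound 1 and from compound 2 to compound 3 therefore cannot be read in size or direction: the limit of > 50000 nM in this assay, at which 3 of the 3 values shown sit.

The compounds shown leave open whether the groups exchanged on the amide-type nitrogen change cytotoxicity at all.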